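The source may hold more compounds than are shown below. What is called first, only, known or untested is meant among the compounds shown, and "the series" means these compounds.

The study bears on an assay on Prostate gland for inhibition of steroid 5-alpha-reductase (Rattus norvegicus); on this read-out lower numbers stand for stronger inhibition and higher numbers for weaker inhibition. Three compounds have been measured there:

Compound 1, `CCCCCCCn1ccc2cc(/C(C)=C/C(=O)Nc3ccccc3OCCCC(=O)O)ccc21`, gives 120 nM.
Compound 2, `CCCC(CC)n1ccc2cc(/C(C)=C/C(=O)Nc3ccccc3OCCCC(=O)O)ccc21`, gives 9.3 nM.
Compound 3, `C/C(=C\C(=O)Nc1ccccc1OCCCC(=O)O)c1ccc2c(ccn2Cc2ccc(C(C)(C)C)cc2)c1`, gives 170 nM.

Compound 2 stands lowest of the three; the nearest number lies a 13-fold lower number from compound 1 to compound 2 (1.11 log units; beyond the scatter) away, the furthest an 18-fold higher number from compound 2 to compound 3 (1.26 log units; beyond the scatter). Compound 4, `C/C(=C\C(=O)Nc1ccccc1OCCCC(=O)O)c1ccc2c(ccn2C(C)c2ccccc2)c1`, differs from compound 2 in one place: 1-phenylethyl in place of 1-ethylbutyl on an aromatic nitrogen. Within the data shown here, two measured steps bear on this change. Where 1-ethylbutyl replaced heptyl the number fell by a 13-fold lower number from compound 1 to compound 2 (1.11 log units; beyond the scatter), and where 4-(tert-butyl)benzyl replaced 1-ethylbutyl it rose by an 18-fold higher number from compound 2 to compound 3 (1.26 log units; beyond the scatter). Compound 1 and compound 3 differ only by a 1.4-fold higher number from compound 1 to compound 3 (0.15 log units; within the scatter), within the scatter. Among the measured compounds shown here, the 1-phenylethyl of compound 4 keeps the branching pattern of the 1-ethylbutyl in compound 2 while bringing a six-membered aromatic ring as in compound 3, so a rise is expected, smaller than the one measured from compound 2 to compound 3. For compound 4 the step expected in this assay is a 3.2-fold higher number from compound 2 to compound 4 (0.51 log units; beyond the scatter). Compound 4 is accordingly estimated at 30 nM, with a range of 10 nM to 100 nM.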

Compound 4, half-maximal inhibitory concentration: 19 nM
The estimate for compound 4 lay 1.6-fold (0.20 log units) above the measured number; low and high end bracket the measured number.
By their numbers in this assay, from the lowest: compound 2; then compound 4; then compounds 1 and 3 (each within the scatter of the next).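

In this assay, the change from 1-ethylbutyl to 1-phenylethyl on the aromatic nitrogen shows that a six-membered aromatic ring can sit in this substituent at only a modest cost (a 2.0-fold higher number from compound 2 to compound 4 (0.31 log units; beyond the scatter)). The ring alone does not set the number, since compound 4 also stands well apart from the 4-(tert-butyl)benzyl compound (an 8.9-fold lower number from compound 3 to compound 4 (0.95 log units; beyond the scatter)). The step from the heptyl compound (a 6.3-fold lower number from compound 1 to compound 4 (0.80 log units; beyond the scatter)) completes a pattern with no exception among these four compounds: the two groups branched at the carbon bound to the nitrogen, in compound 2 and compound 4, give lower numbers than the two groups unbranched at that carbon, in compound 1 and compound 3. Nothing available gives a measured reason for these differences.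

The compounds shown leave open how the two mirror-image forms of 1-phenylethyl compare, and whether the ring or the branch matters more. They also leave open whether the number stays low with a methoxy group or an amine on the phenyl ring of 1-phenylethyl, or with a longer chain at the branching carbon, as in 1-phenylpropyl.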